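The source may report more compounds than this note shows. Statements on the series, on what has been measured and on what is new or still open speak of the compounds shown alone.

Measured compounds and their values:

compound 1 `O=C(C1CC1)N1CCCn2nc(COc3ccccc3)cc21` — 61%
compound 2 `O=C(c1ccccc1F)N1CCCn2nc(COc3ccccc3)cc21` — 62%

In a functional assay on HEK293 cells for positive allosteric modulation of metabotropic glutamate receptor 5 (Homo sapiens), read by calcium flux (on this read-out lower numbers stand for smaller maximal responses and higher numbers for larger maximal responses), compound 2 gives 62%. Going by the values given here, only one other value has been measured, that of compound 1, and the single known step, a number 1 percentage points higher from compound 1 to compound 2 (within the scatter), shows that the two lie within the scatter of each other; on the numbers at hand compound 2 stands alongside compound 1 rather than apart from it.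

Compound 3 `O=C(c1ccc(F)cc1)N1CCCn2nc(COc3ccccc3)cc21` has not yet been measured. It differs from compound 2 by 4-fluorophenyl in place of 2-fluorophenyl on a carbonyl carbon. Among the compounds with values here, the one measured step, 2-fluorophenyl in place of cyclopropyl on a carbonyl carbon, is a different kind of change from the one between compound 2 and compound 3, so no measured step bears directly on it, and the data give no ground for expecting a step beyond the scatter in this assay in either direction.

Compound 3 is therefore estimated at 62%, within a range from 46% to 78%. The expected step from compound 2 to compound 3, no change at the digits printed from compound 2 to compound 3 (within the scatter), is estimated to stay within the scatter.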

Compound 3, largest response reached (reported as percent of maximum), in percent of the reference or control that the assay uses: 63%
Estimate against measurement, compound 3: 1 percentage points below; measured number inside the range.
By their numbers in this assay, from the lowest: compounds 1, 2 and 3 (each within the scatter of the next).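

In this assay, the step from 2-fluorophenyl to 4-fluorophenyl on the carbonyl carbon gives a number 1 percentage points higher from compound 2 to compound 3 (within the scatter), so this read-out does not separate these two fluorophenyl groups, a comparison the earlier pair of a cyclopropyl and a single fluorophenyl could not offer. The replacement of cyclopropyl by 4-fluorophenyl gives a number 2 percentage points higher from compound 1 to compound 3 (within the scatter), which places all three groups on this carbonyl carbon, cyclopropyl, 2-fluorophenyl and 4-fluorophenyl, within the scatter of one another, a statement that holds for these three compounds alone. Nothing at hand speaks to what lies behind this flat result.

From the compounds shown here alone, it remains open whether a group of a different kind on the same carbonyl carbon, such as a plain phenyl, a pyridine, a morpholine, a carboxylic acid or a longer alkyl chain, would stay within the same narrow band or move the maximal response beyond the scatter. Going by these compounds, it also remains open whether the same tolerance would hold once the shared core itself is changed, for all three compounds carry it unaltered.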